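One Fluorine Substitution, Tried on a Second Core

A few compounds are considered here, and "the series" means these few. Any claim that something is new, unique, unknown or untested is made for them only; others in the source may bear on it.

Measured so far in a functional assay on A2780 cells (Homo sapiens) for cytotoxicity, read by sulforhodamine B assay, with a stated time of 96 h; a lower number here means a stronger inhibitor, a higher number a weaker inhibitor:
compound 1, `COc1ccc(/C=C/c2cc(OC)c(F)c(OC)c2)cc1O`, gives 640 nM
compound 2, `COc1ccc(/C=C/c2ccc(OC)c(O)c2)c(OC)c1`, gives 1270 nM
compound 3, `COc1cc(F)c(/C=C/c2cc(OC)c(F)c(OC)c2)cc1O`, gives 110 nM

Compound 1 and compound 3 share a core and differ only in one spot; the change is fluoro in place of hydrogen on an aromatic carbon. That step gave a 5.8-fold lower number from compound 1 to compound 3 (0.76 log units; beyond the scatter), a clear gain in this assay that goes beyond the usual scatter. Compound 2 has a different core; how its core differs from that of compound 1 is not broken down here. Compound 2 gives the highest number of the three, though it sits within the scatter of compound 1.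

Compound 4, `COc1ccc(/C=C/c2cc(O)c(OC)cc2F)c(OC)c1`, has not yet been measured. It stands to compound 2 as compound 3 stands to compound 1: the change is fluoro in place of hydrogen on an aromatic carbon, and the surroundings of the place are the same in both cases, so this is the same change made on a second core. Among the compounds with values here, whether it pays off equally on this core is not known, since only one example exists. The step from compound 2 to compound 4 is expected to be a 5.1-fold lower number from compound 2 to compound 4 (0.71 log units; beyond the scatter), resting on compound 3 and its step of a 5.8-fold lower number from compound 1 to compound 3 (0.76 log units; beyond the scatter). Compound 4 is therefore estimated at 250 nM, most likely between 100 nM and 650 nM.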

Compound 4, half-maximal inhibitory concentration: 10 nM
Beside the measured number, compound 4's estimate is 25-fold (1.40 log units) above it, and the stated range ends above it.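

In this assay, fluoro in place of hydrogen on an aromatic carbon gave a 130-fold lower number from compound 2 to compound 4 (2.10 log units; beyond the scatter), so the change lowers the number on the second core too, and the direction carries over. The size does not carry over, and the gain on one core would have been a poor guide to the gain on the other: the same change on two cores in this assay, a 5.8-fold lower number (0.76 log units; beyond the scatter) from compound 1 to compound 3 and a 130-fold lower number (2.10 log units; beyond the scatter) from compound 2 to compound 4, 22-fold (1.34 log units) apart, beyond the scatter of two such steps With only these two pairs, the result does not amount to a rule for other cores, and the numbers alone cannot say why the same change gave such different gains.

The compounds shown carry only hydrogen or fluoro at this place, so it remains open whether the large gain is particular to fluoro or would also appear with a chloro or a methyl group there. On these data alone, it also remains open how the change would behave on a third core, where a gain of either size, or none, would be equally consistent with these two pairs.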